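Swapping the Sulfonyl Aryl Group of Compound 1

This account rests on a few compounds, and the source may have more. Where it says the series, first, only, none or still open, it means among the compounds named here.

Compound 1 `Cc1ccc(S(=O)(=O)c2cnc3ccc(Cl)cc3c2N2CCC(C)CC2)cc1F` is the lowest of three measured compounds in an assay on isolated protein for displacement of a labelled ligand from metabotropic glutamate receptor 5 (Homo sapiens), with a stated time of 60 min, tested at 1 uM (a higher number here means more inhibition at the concentration tested (going by the name of the read-out), a lower number less inhibition), where compound 1 gives 68%. Compound 2 `Cc1ccc2ncc(S(=O)(=O)c3ccc(C)c(F)c3)c(N3CCC(C)CC3)c2c1` gives 91% in this assay, and compound 3 `Cc1ccc(S(=O)(=O)c2cnc3ccc(F)cc3c2N2CCC(C)CC2)cc1F` gives 86% in this assay. The measured steps are a number 23 percentage points higher from compound 1 to compound 2 (beyond the scatter) and a number 18 percentage points higher from compound 1 to compound 3 (beyond the scatter), while a number 5 percentage points lower from compound 2 to compound 3 (within the scatter). Compound 4 `CC1CCN(c2c(S(=O)(=O)c3ccc(Cl)cc3)cnc3ccc(Cl)cc23)CC1` has not yet been measured. It differs from compound 1 in one place: 4-chlorophenyl in place of 3-fluoro-4-methylphenyl on a sulfonyl sulfur. All three measured steps concern a substituent on an aromatic carbon of the shared core, not the aryl group on the sulfonyl sulfur, so none of them bears directly on this change. Among the measured compounds shown here, with no comparable step among the measured compounds, the change is expected to give a number 8 percentage points lower from compound 1 to compound 4 (within the scatter), a movement that may well lie within the scatter. Compound 4 is accordingly estimated at 60% in this assay, with a range from 35% to 85%.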

Compound 4, a percentage reported as inhibition, at one concentration (the size of the read-out at that concentration, not a potency): 92%
For compound 4 the middle estimate is 32 percentage points below the measured one; measured number above the stated range.
By their numbers in this assay, from the lowest: compound 1; then compounds 3, 2 and 4 (each within the scatter of the next).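

In this assay, the aryl group on the sulfonyl sulfur proves able to move the read-out: with the rest of the molecule unchanged, 4-chlorophenyl in place of 3-fluoro-4-methylphenyl gives a number 24 percentage points higher from compound 1 to compound 4 (beyond the scatter). Among the compounds shown here, the earlier steps all concerned a substituent on an aromatic carbon of the shared core, so this is the first sign that the sulfonyl aryl group matters as well. No measurement at hand accounts for this rise.

Going by these compounds, this single exchange alters fluoro, methyl and chloro together, so the share of each in the step remains open. Also unresolved is whether plain phenyl, 4-methoxyphenyl or a pyridyl group would serve on the sulfonyl sulfur, and whether 4-chlorophenyl would give a similar step in compound 2 and compound 3.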